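Cytotoxicity notes: hydroxymethyl for chloro on compound 3

The source may report more compounds than this note shows. Statements on the series, on what has been measured and on what is new or still open speak of the compounds shown alone.

Measured compounds:
- compound 1, `COc1ccc(Sc2cn(-c3ccc4c(c3)B(O)OC4)c3ccccc23)cc1`; in an ADME assay on L929 cells (Mus musculus) for cytotoxicity, read by resazurin assay, with a stated time of 72 h (a lower number here means a stronger inhibitor, a higher number a weaker inhibitor), compound 1 gives only a limit, > 10 ug/mL.
- compound 2, `OB1OCc2ccc(-n3cc(Sc4ccc5ccccc5c4)c4ccccc43)cc21`; in this assay compound 2 gives only a limit, > 10 ug/mL.
- compound 3, `O=C(c1ccc(Cl)cc1)c1ccn(-c2ccc3c(c2)B(O)OC3)c1`; in this assay compound 3 gives only a limit, > 10 ug/mL.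

Compound 3 therefore stands where every measured value of the series sits, at the limit of > 10 ug/mL in this assay, at which 3 of the 3 values shown sit, and nothing places it apart from compound 1 or compound 2.

The next compound, compound 4, `O=C(c1ccc(CO)cc1)c1ccn(-c2ccc3c(c2)B(O)OC3)c1`, differs from compound 3 in one place: hydroxymethyl in place of chloro on an aromatic carbon.

Among the compounds with values here, only one step between measured compounds exists, a step that the two limits leave unreadable from compound 1 to compound 2, and both ends of it are limits, so its size cannot be read. It also concerns a group on a sulfur, not the ketone-bound ring changed here. Within the data shown here, no measured step therefore bears on the present change, and no direction beyond the scatter can be argued for it.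

With all three measured values at the limit of this assay, compound 4 is expected to remain at or near that limit as well; its estimated value is 15 ug/mL, with a range from 7 ug/mL to 40 ug/mL. The step this expectation means, a step that the limit leaves unreadable from compound 3 to compound 4, is estimated to lie within the scatter.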

Compound 4, half-maximal inhibitory concentration: 9.31 ug/mL
Compound 4: middle estimate off by 1.6-fold (0.21 log units), on the high side; the range from low to high includes it.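

In this assay, within the data shown here, compound 4 gives 9.31 ug/mL, the first value that is a number and not a limit, so a reading can be obtained from this core with a change at this aromatic carbon. Compound 3 gives > 10 ug/mL, which is a limit of the assay. Replacing the 4-chlorophenyl with 4-(hydroxymethyl)phenyl gives an at least 1.0-fold lower number from compound 3 to compound 4 (0.03 log units; that floor lies within the scatter), so the change shows no readable shift beyond the scatter, and its true size stays unknown, with compound 4 now the only numerical reference point against the rest of the series: the limit of > 10 ug/mL in this assay, at which 3 of the 4 values shown sit.

Still open is how large the step really is, since the only step shown at this position has a limit at one end. Also open, as far as these compounds go, is how the number in this assay would respond if a carboxylic acid, an amine or a longer chain ending in hydroxyl stood at the same aromatic carbon in place of hydroxymethyl.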